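Three Esters Measured, a Fourth Awaits Its Reading

The source may report more compounds than this note shows. Statements on the series, on what has been measured and on what is new or still open speak of the compounds shown alone.

Compound 1 `CCCOC(=O)C1=C(C)NC(=S)NC1c1ccoc1`: 4%
Compound 2 `CC1=C(C(=O)OCC(C)C)C(c2ccoc2)NC(=S)N1`: 12%
Compound 3 `COC(=O)C1=C(C)N(C)C(=O)NC1c1ccsc1`: 24%

These three compounds were tested in an assay on membranes from CHO cells for displacement of a labelled ligand from adenosine receptor A1 (Homo sapiens), read by scintillation counting, with a stated time of 60 min, tested at 1 uM; on this read-out higher numbers stand for more inhibition at the one concentration tested (going by the name of the read-out) and lower numbers for less inhibition. Compound 3 gives the highest number of the three, and its steps from compound 2 and from compound 1 lie beyond the scatter, while a number 8 percentage points higher from compound 1 to compound 2 (within the scatter) falls within it. That step is methyl in place of hydrogen on a saturated chain carbon bound to two saturated chain carbons. The difference between the core of compound 1 and the core of compound 3 is not broken down here. Compound 4 `CCOC(=O)C1=C(C)N(C)C(=O)NC1c1ccsc1` is still to be measured in this assay; it differs from compound 3 by methyl in place of hydrogen on a saturated chain carbon bound to an oxygen next to a carbonyl group. This is the same kind of change as between compound 1 and compound 2, but the place differs: there the saturated chain carbon is bound to two saturated chain carbons, here it is bound to an oxygen next to a carbonyl group. Because a number 8 percentage points higher from compound 1 to compound 2 (within the scatter) stayed within the scatter, compound 4 is expected to move by only a number 4 percentage points higher from compound 3 to compound 4 (within the scatter). Compound 4 is estimated at 28%, with a likely range from 12% to 45%.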

Compound 4, a percentage reported as inhibition, at one concentration (the size of the read-out at that concentration, not a potency): 32%
Compound 4: the middle estimate sits 4 percentage points below what was measured; the range from low to high includes it.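

In this assay methyl in place of hydrogen gave a number 8 percentage points higher from compound 3 to compound 4 (within the scatter), and set beside the earlier step it reads the same: the same change on two cores in this assay, a number 8 percentage points higher (within the scatter) from compound 1 to compound 2 and a number 8 percentage points higher (within the scatter) from compound 3 to compound 4, 0 percentage points apart, within the scatter of two such steps
As far as these two pairs go, the change carries from one core to the other with no visible difference in the size of the step. It does not show that the methyl has a real effect on either core, as each step stays within the scatter, and the methyl enters at a different place in each pair.

The compounds shown leave open what a longer chain on the core of compound 3, or a carboxylic acid in place of the ester, would give in this assay.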